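Replacing isopropyl with 4-methoxyphenyl in the aroyl series

This account rests on a few compounds, and the source may have more. Where it says the series, first, only, none or still open, it means among the compounds named here.

In a functional assay on HCT-116 cells (Homo sapiens) for cytotoxicity, read by MTT assay, with a stated time of 72 h (a higher number here means a weaker inhibitor, a lower number a stronger inhibitor), compound 1 (`O=C(c1cccc2ccccc12)n1c(C2CCC2)nc2ccccc21`) reads > 10000 nM, which is a limit of the assay and not a number. Going by the values given here, compound 2 (`COc1ccc(C(=O)n2c(C(C)C)nc3ccccc32)cc1`) gives 190 nM, the only true number available in this small set, so it has no measured neighbour to be ranked against. The next compound to be read is compound 3 (`COc1ccc(C(=O)n2c(-c3ccc(OC)cc3)nc3ccccc32)cc1`). It carries 4-methoxyphenyl in place of isopropyl on an aromatic carbon, between two ring nitrogen atoms (4-methoxyphenyl in place of isopropyl on an aromatic carbon). Among the compounds with values here, no measured pair differs in one place only, so the size of this change has no direct precedent here. Within the data shown here, the expectation is therefore a loose one, resting on the single anchor of compound 2 at 190 nM and on the size of the exchange. In this assay, the expected move is a 3.2-fold higher number from compound 2 to compound 3 (0.50 log units; beyond the scatter), towards weaker inhibition and modestly beyond the scatter, though a change in either direction remains possible. For compound 3, the estimated value is 600 nM, with an expected range of 80 nM to 6000 nM.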

Compound 3, half-maximal inhibitory concentration: > 10000 nM
Compound 3 ended at the assay's limit (the forecaster's own chance of this, stated with the estimate: 15%); middle value at least 16-fold (1.22 log units) from the limit.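

In this assay, the carbon between two ring nitrogen atoms now has its first comparison in which only one place differs, and exchanging isopropyl for 4-methoxyphenyl there gives an at least 52-fold higher number from compound 2 to compound 3 (1.72 log units; beyond the scatter). This position is therefore not indifferent to its substituent: with the rest of compound 2 unchanged, the small open-chain isopropyl gives a measurable value, whereas the larger 4-methoxyphenyl, with its six-membered aromatic ring, does not. Compound 3 reads at a limit of the assay and not at a number, so the step gives only a minimum size, because the read-out ends at this limit: the limit of > 10000 nM in this assay, at which 2 of the 3 values shown sit.

Going by these compounds alone, the single exchange does not separate the contributions of the added aromatic ring, the greater size and the methoxy oxygen, and compound 1 differs from compound 2 in more than one place, so it adds nothing on this point. An unsubstituted phenyl, a cyclopropyl, a tert-butyl or a short amine-bearing chain on this carbon, with the rest of compound 2 kept, would show how far activity extends beyond isopropyl and which part of 4-methoxyphenyl accompanies the loss.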